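The compounds below may be only part of what the source reports. "The series", "measured", "known", "first", "only" and "open" are said of these compounds alone.

Measured compounds:
compound 1, `COc1c(-c2ccccc2)oc2ccc(NC(C)=O)cc2c1=O`, 200000 nM
compound 2, `COc1ccccc1-c1oc2ccc(NC(C)=O)cc2c(=O)c1OC`, 154000 nM
compound 3, `COc1c(-c2ccccc2)oc2ccc(N)cc2c1=O`, 126000 nM

Of the compounds shown here, three have been measured in an ADME assay on MT4 cells (Homo sapiens) for cytotoxicity, read by MTT assay, with a stated time of 4 days (a higher number here means that more compound is tolerated, a lower number that less compound is tolerated), and a fourth, compound 4 with the structure `COc1ccc(-c2oc3ccc(N)cc3c(=O)c2OC)cc1`, is still to be measured. Compound 1 and compound 2 differ only in methoxy in place of hydrogen on an aromatic carbon, and that change gave a 1.3-fold lower number from compound 1 to compound 2 (0.11 log units; within the scatter). Compound 3 and compound 4 differ in methoxy in place of hydrogen on an aromatic carbon, so the same kind of change is made a second time, though not the same change: in compound 2 the methoxy stands ortho to a large group, in compound 4 it stands para to a large group. The two cores on which the change is made differ in hydrogen in place of acetyl on a nitrogen on an aromatic ring, which gave a 1.6-fold lower number from compound 1 to compound 3 (0.20 log units; within the scatter). Among the three measured compounds no step reaches beyond the scatter, so none can be called better or worse tolerated than another.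

The expectation for compound 4 rests on the one earlier occurrence: since compound 2 gave a 1.3-fold lower number from compound 1 to compound 2 (0.11 log units; within the scatter), a step of about the same modest size is expected, namely a 1.1-fold lower number from compound 3 to compound 4 (0.06 log units; within the scatter), with the caveat that the place of the methoxy is not identical. Compound 4 is therefore estimated to give 110000 nM in this assay, with a range from 50000 nM to 250000 nM allowing for the scatter of this kind of measurement.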

Compound 4, half-maximal cytotoxic concentration: 200000 nM
Compound 4: the middle estimate sits 1.8-fold (0.26 log units) below what was measured; the measured number falls inside the stated range.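

In this assay, methoxy in place of hydrogen on an aromatic carbon gave a 1.6-fold higher number from compound 3 to compound 4 (0.20 log units; within the scatter), and this step can be set beside the earlier one on the core of compound 1: the same change on two cores in this assay, a 1.3-fold lower number (0.11 log units; within the scatter) from compound 1 to compound 2 and a 1.6-fold higher number (0.20 log units; within the scatter) from compound 3 to compound 4, 2.1-fold (0.31 log units) apart, within the scatter of two such steps. The two steps therefore cannot be told apart, and on neither core does the change move the number beyond the scatter, so within these four compounds methoxy can be carried from one core to the other without a readable change in how well the compound is tolerated. This does not show that the change acts identically on both cores, nor do the two signs establish a reversal, and the methoxy does not stand at the same place in compound 2 as in compound 4, where it is para to a large group, so the pairs cannot separate the effect of the core from that of the place.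

The compounds shown leave open whether methoxy at one fixed place on both cores would give matching steps. They also leave open whether another group on that aromatic ring, such as a chlorine, a hydroxyl or an ethoxy chain, or a longer acyl chain on the nitrogen, would move the number beyond the scatter.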